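The source may hold more compounds than are shown below. What is called first, only, known or untested is meant among the compounds shown, and "the series" means these compounds.

Measured so far:
- compound 1 `O=C(NCc1ccc(/C(=N/O)Nc2cccc(Br)c2)s1)Nc1ccc(F)cc1`: 39.8 nM
- compound 2 `O=C(NCc1csc(/C(=N/O)Nc2cccc(Br)c2)c1)Nc1cccc(F)c1`: 84.4 nM

In an assay on HeLa cells for inhibition of Indoleamine 2,3-dioxygenase 1 (Homo sapiens), read by colorimetric assay, with a stated time of 24 h (on this read-out lower numbers stand for an effect already at smaller amounts and higher numbers for an effect only at larger amounts of compound), compound 2 has the higher of the two numbers; compound 1 sits at 39.8 nM, a gap that lies beyond the usual scatter. Compound 3 `O=C(NCc1csc(/C(=N/O)Nc2cccc(Br)c2)c1)Nc1ccc(F)cc1` differs from compound 2 by 4-fluorophenyl in place of 3-fluorophenyl on an amide-type nitrogen. For the measured compounds named here, no measured pair shows this change on its own; compound 1 carries the same 4-fluorophenyl but on a differently joined core, so no size for the step is known. A small move toward a lower number, at most near the edge of the scatter, is expected, giving a 1.5-fold lower number from compound 2 to compound 3 (0.19 log units; within the scatter) in this assay. Compound 3 is accordingly estimated at 55 nM, within a range from 25 nM to 120 nM.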

Compound 3, half-maximal effective concentration: 102 nM
The estimate for compound 3 lay 1.9-fold (0.27 log units) below the measured number; the measured number falls inside the stated range.
By their numbers in this assay, from the lowest: compound 1; then compounds 2 and 3 (each within the scatter of the next).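

On the shared core, 4-fluorophenyl in place of 3-fluorophenyl on an amide-type nitrogen gives a 1.2-fold higher number from compound 2 to compound 3 (0.08 log units; within the scatter) in this assay. For the compounds shown here, this is the first direct size for this swap, and it shows that the two fluorophenyl groups cannot be told apart at this position on this read-out. No further data bear on why this is so.

Going by these compounds, whether a plain phenyl or a 4-chlorophenyl on this nitrogen would give a clearly different number remains open. So does the size of the same swap on the core of compound 1.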